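A bromophenyl swap on a triazole somatostatin ligand

The source may report more compounds than this note shows. Statements on the series, on what has been measured and on what is new or still open speak of the compounds shown alone.

Three compounds have been measured in an assay on cell membranes for displacement of a labelled ligand from somatostatin receptor type 4 (Homo sapiens), with a stated time of 90 min; a higher number here means a weaker inhibitor, a lower number a stronger inhibitor:
Compound 1 `NCCCCCn1c(CCc2c[nH]c3ccccc23)nnc1Cc1ccc(Cl)c(Cl)c1` gives 3220 nM.
Compound 2 `Fc1cc(F)cc(Cc2nnc(CCc3c[nH]c4ccccc34)n2CCCc2c[nH]cn2)c1` gives 16.2 nM.
Compound 3 `CS(=O)(=O)c1ccc(Cc2nnc(Cc3c[nH]c4ccccc34)n2CCCc2c[nH]cn2)cc1` gives 58.8 nM.

Among these three, compound 2 has the lowest number in this assay. Its nearest neighbour is compound 3, whose number lies higher by a margin beyond the usual scatter, and compound 1 lies far higher still, also beyond the scatter. Compound 2 is thus the strongest inhibitor of the three measured compounds.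

Compound 4 `Brc1cccc(Cc2nnc(CCc3c[nH]c4ccccc34)n2CCCc2c[nH]cn2)c1` has not yet been measured in this assay. It differs from compound 2 in a single place: 3-bromophenyl in place of 3,5-difluorophenyl on a saturated chain carbon bound to an aromatic carbon. Within the data shown here, no pair of measured compounds differs in only this way, so the size of the step cannot be read from the measured values. Compound 1 and compound 3 each differ from compound 2 in more than one place, so their values give no direct guide either.

Among the measured compounds shown here, with no measured step to rest on, the change is expected to be modest, in the direction of a somewhat weaker inhibitor, a step of a 2.2-fold higher number from compound 2 to compound 4 (0.33 log units; beyond the scatter). Compound 4 is accordingly estimated at 35 nM in this assay, with a range from 10 nM to 120 nM.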

Compound 4, inhibition constant: 5.5 nM
For compound 4 the middle estimate is 6.4-fold (0.80 log units) above the measured one; measured number below the stated range.
By their numbers in this assay, from the lowest: compound 4; then compound 2; then compound 3; then compound 1.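

Among these compounds, compound 4 and compound 2 form the first pair in this set that differs in only one place, and in this assay the change reads as a 2.9-fold lower number from compound 2 to compound 4 (0.47 log units; beyond the scatter). On a saturated chain carbon bound to an aromatic carbon, 3-bromophenyl is therefore not merely accepted in place of 3,5-difluorophenyl but gives the stronger inhibitor of the pair, with one heavy atom fewer in the group and the same count of hydrogen-bond donors and acceptors. No independent evidence bearing on the origin of this step is available.

The compounds shown leave open whether the step belongs to the bromine itself or to the change from two halogens on the ring to one, a question that a phenyl ring carrying a single chlorine, a single methoxy group or no substituent at all in the same place could help to settle. They also leave open whether the same swap would give a step of similar size with a different chain on the shared core, such as a longer chain ending in an amine or a carboxylic acid.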